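The source may hold more compounds than are shown below. What is called first, only, known or untested is meant among the compounds shown, and "the series" means these compounds.

Measured in a functional assay on the whole organism for inhibition, with Rattus norvegicus as the target, read by paw edema; a lower number here means that less compound is needed, a higher number that more compound is needed for the effect:

- compound 1 `CC(=O)Oc1ccc(-n2cccc2)cc1C(=O)O` gives 42 mg/kg
- compound 2 `O=C(O)c1cc(-c2ccns2)ccc1O` gives 80 mg/kg
- compound 3 `O=C(O)c1cc(-n2ccnc2)ccc1O` gives 75 mg/kg

Compound 3 stands second highest of the three numbers, but its gaps to compound 2 and to compound 1 are both within the scatter, so the three cannot be ordered.

Compound 4 `O=C(O)c1cc(-n2ccnn2)ccc1O` differs from compound 3 by 1H-1,2,3-triazol-1-yl in place of 1H-imidazol-1-yl on an aromatic carbon. Among the measured compounds shown here, the one measured step that bears on this, an exchange of one five-membered azole for another at the same place, is a 1.1-fold lower number from compound 2 to compound 3 (0.03 log units; within the scatter), within the scatter. A further azole exchange is therefore expected to give no step beyond the scatter, no change at the digits printed from compound 3 to compound 4 (within the scatter).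

Compound 4 is estimated at 75 mg/kg, with a range of 40 mg/kg to 140 mg/kg.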

Compound 4, dose for half-maximal effect: 150 mg/kg
Compound 4: the middle estimate sits 2.0-fold (0.30 log units) below what was measured; measured number outside the range, above it.
By their numbers in this assay, from the lowest: compounds 1, 3, 2 and 4 (each within the scatter of the next, the first and the last beyond it).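

In this assay, the place meta to a carboxy group and para to a hydroxy group now carries three different five-membered aromatic rings. The exchange for 1H-1,2,3-triazol-1-yl gives a 2.0-fold higher number from compound 3 to compound 4 (0.30 log units; within the scatter) and a 1.9-fold higher number from compound 2 to compound 4 (0.27 log units; within the scatter), so neither step can be separated from the scatter, even with the added ring nitrogen relative to 1H-imidazol-1-yl. No measurement offered here explains these steps. Open, from the compounds shown here alone, is whether a phenyl ring or an amine at this place would give a step beyond the scatter.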